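From a Sulfanyl Link to a Sulfonyl Link

A few compounds are considered here, and "the series" means these few. Any claim that something is new, unique, unknown or untested is made for them only; others in the source may bear on it.

Of the compounds shown here, three have been measured in an ADME assay on HepG2 2.2.15 cells (Homo sapiens) for cytotoxicity, with a stated time of 9 days; on this read-out higher numbers stand for lower toxicity in this test and lower numbers for higher toxicity in this test. Compound 1 `Cc1ccc(SCc2nc3c(Cn4ccnc4)c(O)ccc3n2C)cc1` gives 60800 nM, compound 2 `Cn1c(C[S+]([O-])c2ccccc2)nc2c(Cn3ccnc3)c(O)ccc21` gives 557000 nM, and compound 3 `COc1ccc(SCc2nc3c(Cn4ccnc4)c(O)ccc3n2C)cc1` gives 64500 nM. Compound 3 stands second highest of the three; the step of a 1.1-fold higher number from compound 1 to compound 3 (0.03 log units; within the scatter) lies within the scatter, whereas compound 2, whose linking group holds one oxygen and one sulfur, sits clearly above both. Compound 4 `Cn1c(CS(=O)(=O)c2ccccc2)nc2c(Cn3ccnc3)c(O)ccc21` carries phenylsulfonyl in place of (4-methoxyphenyl)sulfanyl on a saturated chain carbon bound to an aromatic carbon. Among the compounds with values here, the steps that bear on this are a 9.2-fold higher number from compound 1 to compound 2 (0.96 log units; beyond the scatter) and an 8.6-fold lower number from compound 2 to compound 3 (0.94 log units; beyond the scatter), both beyond the scatter and both pointing the same way: adding oxygen on the sulfur link went with a higher number. A similar upward step is expected here, a 6.2-fold higher number from compound 3 to compound 4 (0.79 log units; beyond the scatter). Compound 4 is therefore estimated at 400000 nM, with a range from 150000 nM to 1200000 nM.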

Compound 4, half-maximal cytotoxic concentration: 623000 nM
Compound 4: the middle estimate sits 1.6-fold (0.19 log units) below what was measured; the range from low to high includes it.
By their numbers in this assay, from the lowest: compounds 1 and 3 (each within the scatter of the next); then compounds 2 and 4 (each within the scatter of the next).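

Going further on the sulfur link changes little in this assay: the sulfonyl compound gives a 1.1-fold higher number from compound 2 to compound 4 (0.05 log units; within the scatter), so the second oxygen brings no step beyond the scatter. Both sulfanyl compounds lie well below, with a 9.7-fold higher number from compound 3 to compound 4 (0.98 log units; beyond the scatter) and a 10-fold higher number from compound 1 to compound 4 (1.01 log units; beyond the scatter), so methyl and methoxy on the ring again make no visible difference. Nothing measured here explains these numbers.

Both oxidised links carry a plain phenyl, so the link and the ring substituent remain unseparated. As far as these compounds go, a phenylsulfanyl group, or an amine on that ring, remains open.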